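Estimating compound 4 after swapping nitro for amino

A few compounds are considered here, and "the series" means these few. Any claim that something is new, unique, unknown or untested is made for them only; others in the source may bear on it.

Compound 1, `CCn1cc(-c2nc3ccccc3s2)c(=O)c2cc(F)c(N3CCNCC3)cc21`: in a functional assay on Bel-7402 cells (Homo sapiens) for cytotoxicity, read by MTT assay, with a stated time of 48 h (on this read-out lower numbers stand for stronger inhibition and higher numbers for weaker inhibition), compound 1 gives 24300 nM.
Compound 2, `CCn1cc(-c2nc3ccc(Cl)cc3[nH]2)c(=O)c2cc(F)c(N3CCNCC3)cc21`: in this assay compound 2 gives 2800 nM.
Compound 3, `CCn1cc(-c2nc3ccc([N+](=O)[O-])cc3[nH]2)c(=O)c2cc(F)c(N3CCNCC3)cc21`: in this assay compound 3 gives 2100 nM.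

Compound 3 has the lowest number of the three, though its gap to compound 2 lies within the scatter; only compound 1 sits clearly apart, with an 8.7-fold lower number from compound 1 to compound 2 (0.94 log units; beyond the scatter). Compound 4, `CCn1cc(-c2nc3ccc(N)cc3[nH]2)c(=O)c2cc(F)c(N3CCNCC3)cc21`, differs from compound 3 by amino in place of nitro on an aromatic carbon. For the measured compounds named here, no measured step swaps these two groups. The closest guide is a 1.3-fold lower number from compound 2 to compound 3 (0.12 log units; within the scatter), a change of group at the same place that stayed within the scatter. The expectation for compound 4 in this assay is therefore a step of a 1.4-fold higher number from compound 3 to compound 4 (0.15 log units; within the scatter), likely no larger than the scatter, and the estimate for compound 4 is 3000 nM, ranging from 1000 nM to 9000 nM.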

Compound 4, half-maximal inhibitory concentration: 92100 nM
Compound 4: the middle estimate sits 31-fold (1.49 log units) below what was measured; the measured number lies above the stated range.
By their numbers in this assay, from the lowest: compounds 3 and 2 (each within the scatter of the next); then compound 1; then compound 4.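

Swapping among groups on this aromatic carbon is not always harmless in this assay: chloro and nitro gave values within the scatter of each other, whereas amino brings a 44-fold higher number from compound 3 to compound 4 (1.64 log units; beyond the scatter) and a 33-fold higher number from compound 2 to compound 4 (1.52 log units; beyond the scatter). The amino compound even falls behind the benzothiazole, with a 3.8-fold higher number from compound 1 to compound 4 (0.58 log units; beyond the scatter), so the substituted benzimidazole is no advantage by itself. No supporting data here explain this loss. Still open, from the compounds shown here alone, is whether a methyl, a methoxy or an acetamide group on this carbon would behave like chloro and nitro or like amino.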